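Lengthening the Alkyl Chain on a Shared Core

The source may report more compounds than this note shows. Statements on the series, on what has been measured and on what is new or still open speak of the compounds shown alone.

Compound 3 `CCCc1nn(C)c2c1C(c1ccccc1Cl)=NCC(=O)N2` holds the highest number of the three measured: in a functional assay on the whole organism with Rattus norvegicus as the target (a lower number here means that less compound is needed, a higher number that more compound is needed for the effect), compound 3 requires 250 mg/kg, while compound 1 `Cc1nn(C)c2c1C(c1ccccc1Cl)=NCC(=O)N2` needs 16 mg/kg and compound 2 `CCc1nn(C)c2c1C(c1ccccc1Cl)=NCC(=O)N2` needs 32 mg/kg. Compound 4 `CCCCc1nn(C)c2c1C(c1ccccc1Cl)=NCC(=O)N2` differs from compound 3 in one place: methyl in place of hydrogen on a saturated chain carbon, three bonds along the chain from an aromatic carbon. The two earlier steps along the same chain bear on this: a 2.0-fold higher number from compound 1 to compound 2 (0.30 log units; within the scatter), and a 7.8-fold higher number from compound 2 to compound 3 (0.89 log units; beyond the scatter). The first addition stayed within the scatter, the second clearly raised the dose, so compound 4 is expected to need still more in this assay, a step of a 2.4-fold higher number from compound 3 to compound 4 (0.38 log units; beyond the scatter). The estimate for compound 4 is 600 mg/kg, within a range from 250 mg/kg to 1500 mg/kg.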

Compound 4, minimum effective dose: > 500 mg/kg
Compound 4 ended at the assay's limit; the forecaster's own chance of this, stated with the estimate: 30%; the middle value lies beyond the limit too.
By their numbers in this assay, from the lowest: compounds 1 and 2 (each within the scatter of the next); then compound 3. At a limit, above all of these: compound 4.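

In this assay compound 4 gives > 500 mg/kg, which is a limit of the assay and not a number. Even so, the butyl chain stands far from the two shortest chains, with an at least 15-fold higher number from compound 2 to compound 4 (1.19 log units; beyond the scatter) and an at least 31-fold higher number from compound 1 to compound 4 (1.49 log units; beyond the scatter), so the gap opened by propyl does not close at this position. The last step itself is only a floor, an at least 2.0-fold higher number from compound 3 to compound 4 (0.30 log units; that floor lies within the scatter), and its size stays unknown: the same change on two cores in this assay, a 2.0-fold higher number (0.30 log units; within the scatter) from compound 1 to compound 2 and an at least 2.0-fold higher number (0.30 log units; that floor lies within the scatter) from compound 3 to compound 4; the limit leaves it open whether they differ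

The compounds shown leave open whether a chain carrying an amine or a carboxylic acid in this place would bring the dose back towards that of compound 1.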